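The source may hold more compounds than are shown below. What is called first, only, known or untested is meant among the compounds shown, and "the series" means these compounds.

Among the measured compounds shown here, compound 2 `O=C(/C=C/C=C/c1ccc(OC2CCCC2)cc1)N1CCCCC1` gives the lower of the two numbers measured so far in an assay for inhibition of Polyunsaturated fatty acid 5-lipoxygenase (Homo sapiens), read by spectrophotometry, tested at 20 uM (on this read-out lower numbers stand for less inhibition and higher numbers for more inhibition at the one concentration tested (going by the name of the read-out)), namely 16.1%. Compound 1 `COc1cc(/C=C/C=C/C(=O)N2CCCCC2)cc(OC)c1OC` gives 66.7% in this assay, a value far enough above compound 2 to lie beyond the scatter. The next compound, compound 3 `COc1ccc(/C=C/C=C/C(=O)N2CCCCC2)cc1`, is not yet measured; it differs from compound 2 by methyl in place of cyclopentyl on an oxygen on an aromatic ring. For the measured compounds named here, no measured pair shows this exact change, so the expected step from compound 2 to compound 3 in this assay is only a guess: a modest rise, a number 13.9 percentage points higher from compound 2 to compound 3 (beyond the scatter), that may not clear the scatter. Compound 3 is estimated at 30%, within 10% to 55%.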

Compound 3, a percentage reported as inhibition, at one concentration (the size of the read-out at that concentration, not a potency): 42.6%
Compound 3: middle estimate off by 12.6 percentage points, on the low side; the range from low to high includes it.
By their numbers in this assay, from the lowest: compound 2; then compound 3; then compound 1.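

Swapping cyclopentyloxy for methoxy on the aromatic ring gives a number 26.5 percentage points higher from compound 2 to compound 3 (beyond the scatter) in this assay. Among the compounds shown here, this is the first comparison here in which only one place changes, and it shows that the group on this oxygen affects the inhibition read at the one concentration tested. Between these two compounds, the single-carbon methyl goes with the higher number, but no measurement here explains the step.

Going by these compounds, it remains open how ethyl, isopropyl or a longer chain on this oxygen would read. A free hydroxyl in place of the methoxy is also an open case.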